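Swapping the Aryl Group on the Ring Nitrogen

This account rests on a few compounds, and the source may have more. Where it says the series, first, only, none or still open, it means among the compounds named here.

Compound 1 `COc1cc2c(Oc3ccc(NC(=O)c4nn(-c5ccccc5C(F)(F)F)c(=O)cc4C)cc3F)ccnc2cc1OCCCN1CCCCC1`: 90 nM
Compound 2 `COc1cc2c(Oc3ccc(NC(=O)c4nn(-c5ccccc5C(F)(F)F)c(=O)cc4C)cc3F)ccnc2cc1OCCCN1CCC(C)CC1`: 60 nM

In a functional assay on MKN-45 cells (Homo sapiens) for inhibition, read by MTT assay, with a stated time of 72 h (a higher number here means a weaker inhibitor, a lower number a stronger inhibitor), compound 2 gives 60 nM and compound 1 gives 90 nM; the step of a 1.5-fold lower number from compound 1 to compound 2 (0.18 log units; within the scatter) lies within the scatter, so the two are not separated. Compound 3 `COc1ccc(-n2nc(C(=O)Nc3ccc(Oc4ccnc5cc(OCCCN6CCC(C)CC6)c(OC)cc45)c(F)c3)c(C)cc2=O)cc1` differs from compound 2 in one place: 4-methoxyphenyl in place of 2-(trifluoromethyl)phenyl on an aromatic nitrogen. For the measured compounds named here, the single measured step, a 1.5-fold lower number from compound 1 to compound 2 (0.18 log units; within the scatter), concerns a saturated ring carbon and does not bear on this change, so nothing measured predicts its size or direction. Compound 3 is therefore expected near compound 2, with an estimated step of a 1.5-fold higher number from compound 2 to compound 3 (0.18 log units; within the scatter) and an estimate of 90 nM, ranging from 25 nM to 350 nM.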

Compound 3, half-maximal inhibitory concentration: 400 nM
Estimate against measurement, compound 3: 4.4-fold (0.65 log units) below; measured number outside the range, above it.
By their numbers in this assay, from the lowest: compounds 2 and 1 (each within the scatter of the next); then compound 3.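

In this assay, the aryl group on the aromatic nitrogen proves to be a place where a single change separates two compounds, unlike the methyl on the saturated ring carbon: 4-methoxyphenyl in place of 2-(trifluoromethyl)phenyl gives a 6.7-fold higher number from compound 2 to compound 3 (0.82 log units; beyond the scatter). No measurement at hand accounts for this change in the number. The compounds shown leave open whether the substituent itself or its place on the phenyl ring carries the step. A 2-methoxyphenyl or 4-(trifluoromethyl)phenyl group would separate the two, and a plain phenyl would show how either substituent compares with none.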